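Amide side-chain variation: working notes on a cytotoxicity series

This account rests on a few compounds, and the source may have more. Where it says the series, first, only, none or still open, it means among the compounds named here.

Compound 1 `Cn1c(-c2ccc(NC(=O)CSc3nc4ccccc4o3)cc2)nc(-c2ccccc2)c1-c1ccccc1`: 56.2%
Compound 2 `CN1CCN(CC(=O)Nc2ccc(-c3nc(-c4ccccc4)c(-c4ccccc4)n3C)cc2)CC1`: 33.7%

Going by the values given here, in a functional assay on HT-29 cells (Homo sapiens) for cytotoxicity, read by MTT assay, with a stated time of 24 h, tested at 16 ug/mL (a lower number here means a weaker effect, a higher number a stronger effect of the compound at the concentration tested), compound 1 gives 56.2% and compound 2 gives 33.7%; compound 2 stands lowest of the two, with compound 1 its only neighbour. Among the compounds with values here, the single measured step, a number 22.5 percentage points lower from compound 1 to compound 2 (beyond the scatter), exchanged the whole side-chain group rather than a substituent on it. Compound 3 `Cn1c(-c2ccc(NC(=O)CN3CCN(c4ccccc4)CC3)cc2)nc(-c2ccccc2)c1-c1ccccc1` differs from compound 2 by phenyl in place of methyl on an amine nitrogen in a ring. Within the data shown here, no measured step alters a substituent on the amine nitrogen in a ring, so none bears directly on this change; the expected step is therefore a number 6.3 percentage points higher from compound 2 to compound 3 (within the scatter), small and uncertain in direction. Compound 3 is estimated at 40%, range 22% to 58%.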

Compound 3, a percentage reported as activity, at one concentration (the size of the read-out at that concentration, not a potency): 55.4%
Compound 3: the middle estimate sits 15.4 percentage points below what was measured; measured number inside the range.
By their numbers in this assay, from the lowest: compound 2; then compounds 3 and 1 (each within the scatter of the next).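

On the amine nitrogen in a ring, the substituent matters in this assay: phenyl in place of methyl gives a number 21.7 percentage points higher from compound 2 to compound 3 (beyond the scatter), so the lower number seen with 4-methylpiperazin-1-yl does not carry over to 4-phenylpiperazin-1-yl. The step of a number 0.8 percentage points lower from compound 1 to compound 3 (within the scatter) leaves (1,3-benzoxazol-2-yl)sulfanyl and 4-phenylpiperazin-1-yl not told apart on the saturated chain carbon. Nothing available explains either step. The compounds shown leave open whether this nitrogen needs an aromatic ring or any group of that size will do, a question that a cyclohexyl group there would address.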